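This account rests on a few compounds, and the source may have more. Where it says the series, first, only, none or still open, it means among the compounds named here.

Measured compounds:
- Compound 1 `CCCCCC/C=C/C[C@H]1C[C@@H]([C@@H](O)c2ccccc2)CO[C@@H]1c1ccccc1`: 4990 nM
- Compound 2 `O=[N+]([O-])c1ccc(/C=C/C[C@H]2C[C@@H]([C@@H](O)c3ccccc3)CO[C@@H]2c2ccccc2)cc1`: 4880 nM

Both numbers come from a functional assay on HL-60 cells (Homo sapiens) for cytotoxicity, read by WST assay, with a stated time of 48 h; a lower number here means a stronger inhibitor, a higher number a weaker inhibitor. Compound 1 and compound 2 share the same core and differ only at the end of the side chain, and their two numbers lie within the usual scatter of each other: the step of a 1.0-fold lower number from compound 1 to compound 2 (0.01 log units; within the scatter) is too small to count as a real difference. On the numbers shown, compound 1 therefore cannot be set apart from compound 2.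

Compound 3 `O[C@@H](c1ccccc1)[C@H]1CO[C@H](c2ccccc2)[C@@H](C/C=C/c2ccccc2F)C1` is the next variation on the same theme. Compared with compound 1 the change is 2-fluorophenyl in place of hexyl on a double-bonded chain carbon bound to a double-bonded chain carbon. Among the compounds with values here, the one measured step that bears on this is the move from compound 1 to compound 2, where an aromatic ring also took the place of hexyl on a double-bonded chain carbon bound to a double-bonded chain carbon, and the number in this assay did not move beyond the scatter. There is no measured case of a swap at this place that shifted the number.

On that basis, the step from compound 1 to compound 3 is expected to be a 1.0-fold higher number from compound 1 to compound 3 (0.00 log units; within the scatter), no more than the scatter. Compound 3 is estimated at 5000 nM in this assay, with a range from 2500 nM to 10000 nM.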

Compound 3, half-maximal inhibitory concentration: 9530 nM
Compound 3: middle estimate off by 1.9-fold (0.28 log units), on the low side, and the stated range covers the measured number.
By their numbers in this assay, from the lowest: compounds 2, 1 and 3 (each within the scatter of the next).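

In this assay the swap of hexyl for 2-fluorophenyl on a double-bonded chain carbon bound to a double-bonded chain carbon stays within the scatter (a 1.9-fold higher number from compound 1 to compound 3 (0.28 log units; within the scatter)), and so does the swap of one aromatic end group for the other (a 2.0-fold higher number from compound 2 to compound 3 (0.29 log units; within the scatter)). The flat result from the earlier pair therefore now holds for a second aromatic ring carrying a different substituent: hexyl, 4-nitrophenyl and 2-fluorophenyl cannot be told apart at this place, although both new steps come close to the edge of the scatter, so a small real difference is not ruled out. No other data are at hand to say why the number stays so steady across these end groups.

The compounds shown leave open whether an end group of another kind, such as a carboxylic acid, an amine or a much shorter chain like methyl, would move the number beyond the scatter at this place. As far as these compounds go, they also vary only this one place, so how changes elsewhere on the shared core would affect the number in this assay remains unknown.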